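This account rests on a few compounds, and the source may have more. Where it says the series, first, only, none or still open, it means among the compounds named here.

Measured so far in an assay on isolated protein for displacement of a labelled ligand from 5-hydroxytryptamine receptor 6 (Homo sapiens); a lower number here means a stronger inhibitor, a higher number a weaker inhibitor:

compound 1, `Cn1ccc(S(=O)(=O)c2ccc3c(c2)CCC[C@H]3CN)c1`: compound 1 gives 7.94 nM
compound 2, `NC[C@@H]1CCCc2cc(S(=O)(=O)c3c[nH]c4ccccc34)ccc21`: compound 2 gives 0.0501 nM
compound 3, `O=C1CN=C(NC[C@@H]2CCCc3cc(S(=O)(=O)c4cccc(F)c4)ccc32)N1`: compound 3 gives 0.1 nM

Compound 3 stands second highest of the three numbers. Its nearest neighbour is compound 2, and the two values lie within the scatter of each other, so no order between them can be read. Compound 1 gives the number furthest from compound 3, and that gap lies beyond the scatter.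

Compound 4 `CC(C)(O)C(=O)NC[C@@H]1CCCc2cc(S(=O)(=O)c3cccc(F)c3)ccc21` differs from compound 3 in one place: a group of 6 heavy atoms (4 carbon, 2 oxygen; no ring) in place of a group of 6 heavy atoms (3 carbon, 2 nitrogen, 1 oxygen; one five-membered non-aromatic ring with 2 hetero atoms), on an amine nitrogen

No measured pair in the series shows this change, so the size of the step is not anchored by any shown step. In this assay the step from compound 3 to compound 4 is expected to go toward a higher number, beyond the scatter. Compound 4 is estimated at 10 nM, with a range from 1 nM to 100 nM. The expected step is a 100-fold higher number from compound 3 to compound 4 (2.00 log units; beyond the scatter).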

Compound 4, inhibition constant: 2 nM
The estimate for compound 4 lay 5.0-fold (0.70 log units) above the measured number; the range from low to high includes it.
By their numbers in this assay, from the lowest: compounds 2 and 3 (each within the scatter of the next); then compound 4; then compound 1.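

In this assay, putting (1-hydroxy-1-methylethyl)carbonyl in place of the five-membered non-aromatic ring group on the amine nitrogen gives a 20-fold higher number from compound 3 to compound 4 (1.30 log units; beyond the scatter). Among these compounds, this is the first readable step at this position, and it shows that the choice of group on this nitrogen moves the number. The two groups match in heavy atoms, hydrogen-bond donors and hydrogen-bond acceptors, so those counts alone do not fix the value here. No measurement at hand bears on the reason for this step.

Open, on these data alone, is how an acetyl group or a carboxylic acid on this nitrogen would read with the rest of compound 4 unchanged. Also open, as far as these compounds go, is whether this step keeps its size with the sulfonyl groups of compound 1 or compound 2.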